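A few compounds are considered here, and "the series" means these few. Any claim that something is new, unique, unknown or untested is made for them only; others in the source may bear on it.

Compounds measured so far, in an assay on HEK293 cells for agonist activity at transient receptor potential cation channel subfamily M member 8 (Homo sapiens), read by fluorescence and calcium flux, with a stated time of 15 min; on this read-out higher numbers stand for an effect only at larger amounts of compound and lower numbers for an effect already at smaller amounts:

- compound 1, `Cc1ccc(OCC(=O)N(Cc2cccs2)c2c(C)n[nH]c2C)cc1`: 0.3 nM
- compound 2, `COCCN(Cc1cccs1)C(=O)COc1ccc(C)cc1`: 400 nM
- compound 3, `CCCN(Cc1cccs1)C(=O)COc1ccc(C)cc1`: 40 nM

All three share one core and differ only in the group on the amide-type nitrogen. Compound 3 holds the second highest number of the three: its nearest neighbour is compound 2, with a 10-fold lower number from compound 2 to compound 3 (1.00 log units; beyond the scatter) separating them, while compound 1 lies furthest off, with a 130-fold higher number from compound 1 to compound 3 (2.12 log units; beyond the scatter). The other step, a 1300-fold higher number from compound 1 to compound 2 (3.12 log units; beyond the scatter), shows that exchanging the ring group of compound 1 for an open chain costs a great deal in either case.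

Compound 4, `Cc1ccc(OCC(=O)N(Cc2cccs2)C(C)(C)C)cc1`, is the next member to be tested. Its change from compound 3 is tert-butyl in place of propyl on an amide-type nitrogen. Among the compounds with values here, no measured pair bears directly on this exchange: the two steps that touch compound 3 both concern a ring group or a methoxy group, not a branched alkyl chain. The step from compound 2 to compound 3 is the closest guide, as it is the only one that stays within open-chain groups on this nitrogen, and it was modest. The expected step from compound 3 to compound 4, a 1.6-fold lower number from compound 3 to compound 4 (0.20 log units; within the scatter), is therefore small, with the direction uncertain and a wide margin around it. Compound 4 is estimated at 25 nM, expected to fall between 4 nM and 160 nM in this assay.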

Compound 4, half-maximal effective concentration: 11000 nM
Estimate against measurement, compound 4: 440-fold (2.64 log units) below; measured number outside the range, above it.
By their numbers in this assay, from the lowest: compound 1; then compound 3; then compound 2; then compound 4.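

On the amide-type nitrogen, open-chain groups are not interchangeable in this assay: tert-butyl in place of propyl gives a large loss (a 280-fold higher number from compound 3 to compound 4 (2.44 log units; beyond the scatter)), although no ring enters and the counts of hydrogen-bond donors and acceptors and the net charge stay the same. The earlier open-chain comparison spanned only a modest step, whereas tert-butyl also falls clearly behind 2-methoxyethyl (a 28-fold higher number from compound 2 to compound 4 (1.44 log units; beyond the scatter)), so compound 2 no longer marks the poor end of the series, and the range at this position widens to the step from the 3,5-dimethyl-1H-pyrazol-4-yl group (a 37000-fold higher number from compound 1 to compound 4 (4.56 log units; beyond the scatter)). No measurement at hand accounts for the sharp response to this small exchange.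

On these data alone, it remains open whether the loss follows from branching in general or specifically from the fully substituted carbon on the nitrogen, a question that isopropyl, isobutyl or a straight butyl chain at this position would address. Also open, as far as these compounds go, is whether another ring there, such as phenyl or cyclohexyl, would come close to compound 1 (0.3 nM).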